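The compounds below may be only part of what the source reports. "The series", "measured", "known", "first", "only" and "open" are said of these compounds alone.

Compound 1 `CCNC(=O)CCCOc1ccc(-c2nc3ncccn3c2NC2CCCCC2)cc1` gives in a toxicity assay on A549 cells (Homo sapiens) for cytotoxicity, read by luminescence and CellTiter-Glo, with a stated time of 48 h; on this read-out lower numbers stand for higher toxicity in this test and higher numbers for lower toxicity in this test > 100000 nM, which is a limit of the test rather than a number.
Compound 2 `COCCCCOc1ccc(-c2nc3ncccn3c2NC2CCCCC2)cc1` gives in this assay 100000 nM.
Compound 3 `COc1ccc(-c2nc3ncccn3c2NC2CCCCC2)cc1` gives in this assay > 100000 nM, again a limit of the test.

Compound 3 thus stands at the limit, as the limit of > 100000 nM in this assay, at which 2 of the 3 values shown sit, shows. The measured steps leave little to read: a number no higher from compound 1 to compound 2 (the limit leaves the size open), a step that the two limits leave unreadable from compound 1 to compound 3 and a number no lower from compound 2 to compound 3 (the limit leaves the size open). Compound 4 `c1ccc(-c2nc3ncccn3c2NC2CCCCC2)cc1` differs from compound 3 by hydrogen in place of methoxy on an aromatic carbon. Among the measured compounds shown here, no measured step covers this change, and compound 1, compound 2 and compound 3 all sit at the limit of > 100000 nM in this assay, at which 2 of the 3 values shown sit, or at that same number, so compound 4 is expected to stay there as well. The expected step is a number no higher from compound 3 to compound 4 (the limit leaves the size open), nothing beyond the scatter. The estimate for compound 4 in this assay is 100000 nM, with a range from 50000 nM to 200000 nM.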

Compound 4, half-maximal cytotoxic concentration: 100000 nM
The estimate for compound 4 equals the measured number at the digits printed; measured number inside the range.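

In this assay, hydrogen in place of 4-methoxybutoxy on an aromatic carbon gives no change at the digits printed from compound 2 to compound 4 (within the scatter). The long chain and a bare hydrogen therefore read alike at this position, so compound 4 shows that this pair needs no group there to give this reading. Hydrogen in place of methoxy on an aromatic carbon gives a number no higher from compound 3 to compound 4 (the limit leaves the size open), and hydrogen in place of 3-(ethylcarbamoyl)propoxy on an aromatic carbon gives a number no higher from compound 1 to compound 4 (the limit leaves the size open); the size of these two steps cannot be read, because each starts from a limit of the test: the limit of > 100000 nM in this assay, at which 2 of the 4 values shown sit.

On these data alone, whether an amine or a carboxylic acid on this aromatic carbon would lower the number remains open. So does the effect of replacing the cyclohexylamino group with a different amine.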